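Trading (pyridin-2-yl)methoxy for ethoxy on a shared core

The source may hold more compounds than are shown below. What is called first, only, known or untested is meant among the compounds shown, and "the series" means these compounds.

In a physicochemical assay for lipophilicity, read by HPLC, at pH 7.4 (on this read-out higher numbers stand for higher lipophilicity and lower numbers for lower lipophilicity), compound 1 `O=C(O)CCn1c(=O)oc2cc(Cl)c(Cl)cc21` gives 1.61 while compound 2 `O=C(O)CCn1c(=O)oc2cc(OCc3ccccn3)c(Cl)cc21` gives 1.32 and the two numbers lie within the scatter of each other. Compound 3 `CCOc1cc2oc(=O)n(CCC(=O)O)c2cc1Cl` has not been measured and differs from compound 2 at one place: methyl in place of pyridin-2-yl on a saturated chain carbon bound to an oxygen on an aromatic ring with methyl in place of pyridin-2-yl on a saturated chain carbon bound to an oxygen on an aromatic ring, which reads as (pyridin-2-yl)methoxy to ethoxy. For the measured compounds named here, one measured step bears on this: a number 0.29 log units lower from compound 1 to compound 2 (within the scatter) for (pyridin-2-yl)methoxy in place of chloro on an aromatic carbon. That step stayed within the scatter and does not test ethoxy itself, so no step beyond the scatter is expected in this assay here. The expected step is a number 0.03 log units higher from compound 2 to compound 3 (within the scatter) on this reasoning. The estimate for compound 3 is 1.35 with 1.05 to 1.65 as its expected range.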

Compound 3, distribution coefficient: 1.49
Estimate against measurement, compound 3: 0.14 log units below, within the range that was stated.
By their numbers in this assay, from the lowest: compounds 2, 3 and 1 (each within the scatter of the next).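

In this assay, ethoxy in place of (pyridin-2-yl)methoxy gives a number 0.17 log units higher from compound 2 to compound 3 (within the scatter) and so shows that methyl can replace pyridin-2-yl on the saturated chain carbon, with its six-membered aromatic ring gone, without a step beyond the scatter. Ethoxy in place of chloro on the aromatic carbon gives a number 0.12 log units lower from compound 1 to compound 3 (within the scatter) and so adds a second oxygen-linked group that stays within the scatter of chloro, which leaves chloro, (pyridin-2-yl)methoxy and ethoxy all within the scatter of one another at this position. No evidence on the reason for this accompanies these results.

The compounds shown leave open whether an amine or a carboxylic acid on this aromatic carbon would stay within the scatter too. They also leave open whether a longer chain on the oxygen would do the same.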